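The source may report more compounds than this note shows. Statements on the series, on what has been measured and on what is new or still open speak of the compounds shown alone.

Compound 1 `Cc1nc(-c2ccccc2)c(C(=O)N2CCN(c3cccc(C(N)=O)c3)CC2)o1`: 71 nM
Compound 2 `Cc1nc(-c2ccccc2)c(C(=O)N2CCN(c3ccc(F)cc3)CC2)o1`: > 1000 nM

In a functional assay on HL-60 cells (Homo sapiens) for inhibition, read by MTT assay, with a stated time of 72 h (a higher number here means a weaker inhibitor, a lower number a stronger inhibitor), compound 1 gives 71 nM. Compound 2 is reported only as a limit of the assay, > 1000 nM, and so sits at the limit of > 1000 nM in this assay, at which 1 of the 2 values shown sits. Compound 3 `Cc1nc(-c2ccccc2)c(C(=O)N2CCN(c3ccc(C)c(C)c3)CC2)o1` is not yet measured; it differs from compound 2 by 3,4-dimethylphenyl in place of 4-fluorophenyl on an amine nitrogen in a ring. Among the compounds with values here, the one measured step, an at least 14-fold higher number from compound 1 to compound 2 (1.14 log units; beyond the scatter), shows that 3-carbamoylphenyl on this ring nitrogen gave a much stronger inhibitor than 4-fluorophenyl. A 3,4-dimethylphenyl brings no carbamoyl back, so compound 3 is expected to stay weak, with an expected step that the limit leaves unreadable from compound 2 to compound 3 and probably again only a limit. The estimate for compound 3 is 1500 nM, between 500 nM and 5000 nM.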

Compound 3, half-maximal inhibitory concentration: 43 nM
Beside the measured number, compound 3's estimate is 35-fold (1.54 log units) above it, outside the stated range (below it).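

In this assay, a strong inhibitor does not need a carbamoyl group on this ring nitrogen: 3,4-dimethylphenyl in place of 4-fluorophenyl gives an at least 23-fold lower number from compound 2 to compound 3 (1.36 log units; beyond the scatter). Replacing 3-carbamoylphenyl with 3,4-dimethylphenyl gives a 1.7-fold lower number from compound 1 to compound 3 (0.22 log units; within the scatter), so these two groups cannot be told apart here. The size of the first step rests on a limit for compound 2: the limit of > 1000 nM in this assay, at which 1 of the 3 values shown sits.

Why 4-fluorophenyl gives so much weaker a result stays open. So does what a phenyl ring carrying a single methyl group, a chlorine or an amine would give.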